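The source may hold more compounds than are shown below. What is called first, only, known or untested is meant among the compounds shown, and "the series" means these compounds.

Measured in a functional assay on A2780 cells (Homo sapiens) for cytotoxicity; on this read-out lower numbers stand for stronger inhibition and higher numbers for weaker inhibition:
- compound 1 `CC(C)C(=O)Nc1ncc(SCc2ncc(C(C)(C)C)o2)s1`: 50 nM
- compound 2 `CC(C)(C)C(=O)Nc1ncc(SCc2ncc(C(C)(C)C)o2)s1`: 250 nM
- compound 3 `CC(C)(C)c1cnc(CSc2cnc(NC(=O)OCc3ccccc3)s2)o1`: 1040 nM

Of these three, compound 3 has the highest number, 1040 nM, which makes it the weakest. The change to compound 4 `CC(C)(C)c1cnc(CSc2cnc(NC(=O)Nc3c(F)cccc3F)s2)o1` is a single swap: (2,6-difluorophenyl)amino in place of benzyloxy on a carbonyl carbon. In short, (2,6-difluorophenyl)amino takes the place of benzyloxy on a carbonyl carbon, and the rest of the molecule stays the same.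

Among the compounds with values here, no measured compound carries the entering group, so no measured step tests this swap directly. The closest evidence comes from changes at the same carbonyl carbon. The largest is a 21-fold higher number from compound 1 to compound 3 (1.32 log units; beyond the scatter), and a smaller one is a 4.2-fold higher number from compound 2 to compound 3 (0.62 log units; beyond the scatter). Even the small difference between the isopropyl and tert-butyl groups gives a 5.0-fold higher number from compound 1 to compound 2 (0.70 log units; beyond the scatter). Changes at this place have therefore moved the number clearly in all three pairs, so a swap here may well matter too. Within the data shown here, compound 3 already sits at the top of this small range with 1040 nM, so a modest step towards lower numbers seems the likelier outcome, though with only three compounds this is uncertain.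

The estimated change is a 2.6-fold lower number from compound 3 to compound 4 (0.41 log units; beyond the scatter).

For compound 4 the expected value is 400 nM, with an estimated range of 80 nM to 2000 nM.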

Compound 4, half-maximal inhibitory concentration: 240 nM
Estimate against measurement, compound 4: 1.7-fold (0.22 log units) above; low and high end bracket the measured number.
By their numbers in this assay, from the lowest: compound 1; then compounds 4 and 2 (each within the scatter of the next); then compound 3.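

In this assay, the swap gives a 4.3-fold lower number from compound 3 to compound 4 (0.64 log units; beyond the scatter), which shows that a group carrying a six-membered aromatic ring need not sit at the top of the range at this carbonyl carbon. The new group cannot be told apart from tert-butyl, with a 1.0-fold lower number from compound 2 to compound 4 (0.02 log units; within the scatter), but it does not match isopropyl, with a 4.8-fold higher number from compound 1 to compound 4 (0.68 log units; beyond the scatter), so compound 1 remains the strongest of the four. No measurement here explains why any of these groups shifts the number as it does.

The swap changes several things at once, since an amino nitrogen carrying a hydrogen replaces the oxygen, the chain carbon of benzyloxy is gone and two fluorines enter, so the compounds shown cannot say which of these changes accounts for the step. A plain phenylamino group and a benzylamino group would help separate these changes, while a cyclopropyl or ethyl group at the same carbonyl carbon would show how narrowly the low number of compound 1 depends on isopropyl.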